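Single enantiomer of the chloro acid: compound 4

The source may report more compounds than this note shows. Statements on the series, on what has been measured and on what is new or still open speak of the compounds shown alone.

In an assay for inhibition of sodium- and chloride-dependent glycine transporter 1 (Homo sapiens) (a lower number here means a stronger inhibitor, a higher number a weaker inhibitor), the three measured compounds sit in a clear order. Compound 1 `COc1ccc(Sc2ccc(Cl)cc2N2CCN(CC(=O)O)C(C)C2)cc1` gives 290 nM, the lowest of the three numbers. Compound 2 `COc1ccc(Sc2ccccc2N2CCN(CC(=O)O)C(C)C2)cc1` gives 1700 nM, and compound 3 `COc1ccc(Sc2ccc(OC)cc2N2CCN(CC(=O)O)C(C)C2)cc1` gives 4600 nM. The steps among them are all beyond the scatter: a 5.9-fold higher number from compound 1 to compound 2 (0.77 log units; beyond the scatter), a 16-fold higher number from compound 1 to compound 3 (1.20 log units; beyond the scatter) and a 2.7-fold higher number from compound 2 to compound 3 (0.43 log units; beyond the scatter). Compound 1 is thus the strongest inhibitor of the set, with compound 2 nearest to it and compound 3 furthest away.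

Compound 4 `COc1ccc(Sc2ccc(Cl)cc2N2CCN(CC(=O)O)[C@@H](C)C2)cc1` keeps every atom and bond of compound 1; the only difference is the two compounds have the same atoms and bonds; at least one stereo element is drawn with a configuration in one of them and without one in the other: 1 of 1 stereo elements differ; a stereocentre at a saturated ring carbon is drawn without a configuration in compound 1 and S in compound 4. None of the three measured steps touches this stereocentre, since each of them changes a group on an aromatic carbon. The data therefore give no direct guide to the size or direction of the step in this assay. A single configuration drawn out from a compound drawn without one may give a somewhat lower number or a clearly higher one; with the number of compound 1 at 290 nM as the only anchor, compound 4 is estimated at 250 nM, within 90 nM to 2500 nM, which amounts to an expected step of a 1.2-fold lower number from compound 1 to compound 4 (0.06 log units; within the scatter).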

Compound 4, half-maximal inhibitory concentration: 1400 nM
The estimate for compound 4 lay 5.6-fold (0.75 log units) below the measured number; measured number inside the range.
By their numbers in this assay, from the lowest: compound 1; then compounds 4 and 2 (each within the scatter of the next); then compound 3.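

Among these compounds, every earlier step in this assay changed a group on an aromatic carbon, so this is the first reading of the saturated ring carbon, and the number responds to its configuration even with the chloro group and the rest of the core unchanged: fixing this carbon as S gives a 4.8-fold higher number from compound 1 to compound 4 (0.68 log units; beyond the scatter). The S form alone therefore does not reproduce the low number of compound 1, which is drawn without a configuration at this carbon. The step can be assigned to this stereocentre and nothing else, because no other feature separates the two structures: the fact that one of compounds 1 and 4 is drawn with a defined configuration and the other without, at the place where they differ

The compounds shown leave open how the R configuration at this carbon would read in this assay, and so whether it would give a number lower than that of compound 1, and whether the order of chloro, hydrogen and methoxy on the aromatic carbon holds once the ring carbon has a fixed configuration. They also leave open how an ethyl group on that ring carbon, or an amide in place of the carboxylic acid, would read in this series.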